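Trading the acetyl-methoxyphenoxy tail for a benzyl group

This account rests on a few compounds, and the source may have more. Where it says the series, first, only, none or still open, it means among the compounds named here.

Compound 1, `COc1cc(C(C)=O)ccc1OCCCN1CCC(C(c2ccc(C)cc2)c2ccc(C)cc2)CC1`: in a functional assay (aorta) with Oryctolagus cuniculus as the target (a higher number here means weaker binding, a lower number tighter binding), compound 1 gives 15.9 nM.
Compound 2, `COc1cc(C(C)=O)ccc1OCCCN1CCC(C(O)(c2ccc(F)c(F)c2)c2ccc(F)c(F)c2)CC1`: in this assay compound 2 gives 2.51 nM.
Compound 3, `COc1cc(OCCCN2CCC(C(c3ccc(F)cc3)c3ccc(F)cc3)CC2)ccc1C(C)=O`: in this assay compound 3 gives 3.16 nM.

Compound 3 stands second highest of the three numbers. Its nearest neighbour is compound 2, whose number is lower by a margin that lies within the usual scatter, so the two cannot be placed in order. Compound 1 lies furthest away, with the higher number, and that gap is beyond the scatter.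

Compound 4, `Fc1ccc(C(c2ccc(F)cc2)C2CCN(CCCCc3ccccc3)CC2)cc1`, has not yet been measured. It differs from compound 3 in one place: benzyl in place of 4-acetyl-3-methoxyphenoxy on a saturated chain carbon, three bonds along the chain from an amine nitrogen in a ring. For the measured compounds named here, all hydrogen-bond acceptors of the leaving group disappear, and no measured pair shows what this exchange does on its own.

On the whole, compound 4 is expected to give a somewhat weaker result than compound 3 in this assay, a step of a 3.2-fold higher number from compound 3 to compound 4 (0.50 log units; beyond the scatter) that is expected to lie just beyond the scatter. Compound 4 is estimated at 10 nM, with a range from 3 nM to 40 nM.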

Compound 4, dissociation constant: 2.51 nM
The estimate for compound 4 lay 4.0-fold (0.60 log units) above the measured number; measured number outside the range, below it.
By their numbers in this assay, from the lowest: compounds 2, 4 and 3 (each within the scatter of the next); then compound 1.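

The exchange of 4-acetyl-3-methoxyphenoxy for benzyl on a saturated chain carbon, three bonds along the chain from an amine nitrogen in a ring, reads as a 1.3-fold lower number from compound 3 to compound 4 (0.10 log units; within the scatter), so the two groups cannot be told apart at this position in this assay. This first matched pair shows that the whole 4-acetyl-3-methoxyphenoxy group, hydrogen-bond acceptors included, can leave without a change beyond the scatter, as long as a benzyl group takes its place. No measurement is at hand that would explain this result.

As far as these compounds go, it remains open whether the same exchange would read alike with the different diaryl portions of compound 1 and compound 2. Also open, from the compounds shown here alone, is what a carboxylic acid or an amide would give at this place in place of benzyl.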